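Swapping fluoro for dimethylamino on a shared hydrazone core

The source may hold more compounds than are shown below. What is called first, only, known or untested is meant among the compounds shown, and "the series" means these compounds.

Of the compounds shown here, two built on the same core have so far been tested in an ADME assay on J774 cells (Mus musculus) for cytotoxicity, read by MTT assay, with a stated time of 48 h, tested at 100 ug/mL; on this read-out higher numbers stand for a weaker effect at the one concentration tested and lower numbers for a stronger effect. Compound 1, `O=C(N/N=C/c1ccc(F)cc1)c1cnccn1`, carries a fluoro group on its outer benzene ring; in this assay compound 1 gives 69%. Compound 2, `COc1ccccc1/C=N/NC(=O)c1cnccn1`, carries a methoxy group instead; in this assay compound 2 gives 100%. Of these two numbers, compound 1 stands lowest, and its distance from compound 2 lies beyond the usual scatter, so compound 1 shows the stronger effect on the cells of the pair.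

Compound 3, `CN(C)c1ccc(/C=N/NC(=O)c2cnccn2)cc1`, has not been measured yet. It differs from compound 1 in a single place: dimethylamino in place of fluoro on an aromatic carbon. For the measured compounds named here, no pair of measured compounds shows this kind of change, so there is no measured step to lean on; only the two values above and the change itself are available.

Given that compound 2 with its different substituent reached 100%, a move in compound 3 toward a weaker effect seems somewhat more likely than a further fall, though a change of either sign within the scatter is also plausible. Compound 3 is therefore expected to land near 85%, somewhere between 60% and 105%, a step from compound 1 to compound 3 estimated at a number 16 percentage points higher from compound 1 to compound 3 (beyond the scatter).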

Compound 3, a percentage reported as activity, at one concentration (the size of the read-out at that concentration, not a potency): 87%
Estimate against measurement, compound 3: 2 percentage points below; low and high end bracket the measured number.
By their numbers in this assay, from the lowest: compound 1; then compound 3; then compound 2.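

In this assay, putting dimethylamino in place of fluoro on the aromatic carbon para to a large group gives a number 18 percentage points higher from compound 1 to compound 3 (beyond the scatter), a modest step. For the compounds shown here, this is the first measured sign that the group at this position of the shared core can shift the read-out: the entering dimethylamino, with more heavy atoms and one hydrogen-bond acceptor, goes along with a weaker effect on the cells at the one concentration tested. Nothing measured here points to what lies behind this shift.

From the compounds shown here alone, a single swap cannot separate what leaving fluoro contributes from what dimethylamino brings, so it remains open how a plain hydrogen, a primary amine or a carboxylic acid on the same carbon would read. Going by these compounds, each number also describes the size of the effect at one concentration rather than a potency, so it also remains open whether the step would hold at other concentrations.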